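Shifting a Fluoro Substituent on the Benzamido Group

The source may hold more compounds than are shown below. What is called first, only, known or untested is meant among the compounds shown, and "the series" means these compounds.

Of the compounds shown here, two sharing one core have been measured so far. Compound 1 `CN1CCN(c2ccc(Nc3nc(-c4cccc(NC(=O)c5ccc(F)cc5)c4)sc3C(N)=O)cc2)CC1` carries a fluoro on its benzamido ring, and in a functional assay on Raji cells (Homo sapiens) for antiproliferative activity, read by CCK-8 assay, with a stated time of 72 h, tested at 40 uM (a higher number here means more inhibition at the concentration tested (going by the name of the read-out), a lower number less inhibition), compound 1 gives 95.3%. Compound 2 `CN1CCN(c2ccc(Nc3nc(-c4cccc(NC(=O)c5ccccc5)c4)sc3C(N)=O)cc2)CC1` has a hydrogen in that place instead, and in this assay compound 2 gives 91.3%. Among the compounds with values here, the one step between them, a number 4 percentage points lower from compound 1 to compound 2 (within the scatter), is too small to separate the two. Compound 2 therefore holds the lower of the two numbers, yet it stands within the scatter of compound 1, so no real difference between them can be claimed.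

Compound 3 `CN1CCN(c2ccc(Nc3nc(-c4cccc(NC(=O)c5cccc(F)c5)c4)sc3C(N)=O)cc2)CC1` differs from compound 2 in a single place: fluoro in place of hydrogen on an aromatic carbon. The benzamido group thus becomes ((3-fluorophenyl)carbonyl)amino. Within the data shown here, the only measured step that bears on this change is a number 4 percentage points lower from compound 1 to compound 2 (within the scatter), where removing a fluoro from the same ring moved the number by an amount within the scatter. A fluoro entering that ring again is therefore expected to leave the read-out essentially unchanged, an expected step of a number 0.7 percentage points higher from compound 2 to compound 3 (within the scatter). For compound 3 the estimated value in this assay is 92%, within a range from 80% to 98%.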

Compound 3, a percentage reported as inhibition, at one concentration (the size of the read-out at that concentration, not a potency): 2.78%
Compound 3: middle estimate off by 89.2 percentage points, on the high side; the measured number lies below the stated range.
By their numbers in this assay, from the lowest: compound 3; then compounds 2 and 1 (each within the scatter of the next).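

In this assay, the effect of a fluoro on this ring depends strongly on where it sits. Going from the plain phenyl to the 3-fluorophenyl group gives a large drop (a number 88.5 percentage points lower from compound 2 to compound 3 (beyond the scatter)), and exchanging the 4-fluorophenyl group for the 3-fluorophenyl group, which keeps the same atoms and changes only the fluoro's place, gives a similar one (a number 92.5 percentage points lower from compound 1 to compound 3 (beyond the scatter)). The earlier pair showed numbers level within the scatter, but one fluorine atom on this carbon now separates a high number from a very low one, and nothing available here accounts for that difference.

On these data alone, it remains open whether this loss belongs to fluoro in particular or would follow any group on the same carbon, and a chloro, a methyl or a methoxy there would help to tell these apart. Each number is also a reading at a single concentration, so how the potencies of these compounds compare remains open as well.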